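A fluoro on the phenyl ring of a chalcone

The compounds below may be only part of what the source reports. "The series", "measured", "known", "first", "only" and "open" are said of these compounds alone.

Measured so far:
Compound 1, `COc1cc(OC)c(OC)cc1/C=C/C(=O)c1ccc(O)cc1O`: 33800 nM
Compound 2, `COc1cc(OC)c(OC)cc1/C=C/C(=O)c1ccccc1`: > 150000 nM

In a functional assay on MCF7 cells (Homo sapiens) for inhibition, read by MTT assay, with a stated time of 72 h (on this read-out higher numbers stand for weaker inhibition and lower numbers for stronger inhibition), compound 1 gives 33800 nM. Compound 2 gives > 150000 nM, which is a limit of the assay and not a number. For the measured compounds named here, the one measured step, an at least 4.4-fold higher number from compound 1 to compound 2 (0.64 log units; beyond the scatter), runs toward weaker inhibition, and it ends at the limit of > 150000 nM in this assay, at which 1 of the 2 values shown sits, so compound 2 stands at the weak edge of what this assay can report.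

Compound 3, `COc1cc(OC)c(OC)cc1/C=C/C(=O)c1ccc(F)cc1`, has not yet been measured. It differs from compound 2 by fluoro in place of hydrogen on an aromatic carbon. No measured step involves a fluoro, so nothing among the shown numbers tells how this change should move this assay. The only step shown, from compound 1 to compound 2, concerns the loss of two hydroxy groups and does not touch the question. With compound 2 already sitting at the limit, compound 3 is expected most likely to stay there as well. The expected step is a number no higher from compound 2 to compound 3 (the limit leaves the size open), within the scatter. Compound 3 is estimated at 150000 nM, in a range from 50000 nM to 400000 nM.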

Compound 3, half-maximal inhibitory concentration: 30000 nM
Compound 3: middle estimate off by 5.0-fold (0.70 log units), on the high side, outside the stated range (below it).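

The phenyl ring of compound 2 is not a dead end in this assay: a single fluoro, para to a large group, gives an at least 5.0-fold lower number from compound 2 to compound 3 (0.69 log units; beyond the scatter), so this one change is enough to bring the read-out to a measured number. The hydroxy groups of compound 1 are therefore not the only ring substitution among these compounds that gives a measured number, and the comparison with the fluoro compound shows no separation between the two rings: a 1.1-fold lower number from compound 1 to compound 3 (0.05 log units; within the scatter). The true size of the fluoro step stays unknown, and only its lower bound can be read, because the value for compound 2 is a limit of the assay and not a number: the limit of > 150000 nM in this assay, at which 1 of the 3 values shown sits.

From the compounds shown here alone, whether the change depends on fluoro itself stays open, since a chloro, a methoxy or an amino group at the same place would be needed to tell. The compounds shown also leave open whether a fluoro elsewhere on this ring, or a single hydroxy group in its place, would give a similar number.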